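Amide nitrogen substituent change at the assay limit

The source may report more compounds than this note shows. Statements on the series, on what has been measured and on what is new or still open speak of the compounds shown alone.

The series shares the core of compound 1 `COc1cc([C@H]2C[C@]2(CO)C(=O)Nc2ccccc2Cl)cc(OC)c1OC`, which in a functional assay on SW480 cells (Homo sapiens) for cytotoxicity, read by MTT assay, with a stated time of 48 h (on this read-out higher numbers stand for weaker inhibition and lower numbers for stronger inhibition), gives 40200 nM. Compound 2 `CCOC(=O)[C@]1(C(=O)Nc2ccccc2Cl)C[C@@H]1c1cc(OC)c(OC)c(OC)c1` returns in this assay only a limit, > 100000 nM. Compound 3 `CCOC(=O)[C@@]1(C(=O)Nc2ccccc2Cl)C[C@H]1c1cc(OC)c(OC)c(OC)c1` is the mirror image of compound 2, and in this assay compound 3 gives 30100 nM. The two measured steps are an at least 2.4-fold higher number from compound 1 to compound 2 (0.39 log units; beyond the scatter) and an at least 3.3-fold lower number from compound 2 to compound 3 (0.52 log units; beyond the scatter), the second resting on (the fact that compounds 2 and 3 differ only in the configuration as drawn). Where compound 2 stands is known only through (the limit of > 100000 nM in this assay, at which 1 of the 3 values shown sits), so no number is available for it.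

Compound 4 `CCOC(=O)[C@]1(C(=O)NCc2ccc(C)cc2)C[C@@H]1c1cc(OC)c(OC)c(OC)c1` differs from compound 2 at the amide-type nitrogen: 4-methylbenzyl in place of 2-chlorophenyl on an amide-type nitrogen. Neither measured step touches this nitrogen; one concerns the saturated ring carbon and the other the configuration as drawn, so neither gives a size or a direction for the present change. Compound 2 already sits at the limit, and the series holds no comparison from which a move away from that limit could be read. Compound 4 is therefore expected to remain near the limit, with an expected step of a number no higher from compound 2 to compound 4 (the limit leaves the size open). The estimate for compound 4 is 100000 nM, within 30000 nM to 300000 nM.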

Compound 4, half-maximal inhibitory concentration: > 100000 nM
Compound 4 gave a limit, no number; the forecaster's own chance of this, stated with the estimate: 60%; the middle value lies on the limit itself.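

In this assay, compound 2 and compound 4 both return only a limit, so the step between them cannot be read: the limit of > 100000 nM in this assay, at which 2 of the 4 values shown sit.

The compounds shown leave open whether 4-methylbenzyl in place of 2-chlorophenyl on an amide-type nitrogen moves the read-out at all, and in which direction.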